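Cytotoxicity notes: chloro to hydrogen step from compound 3

The source may hold more compounds than are shown below. What is called first, only, known or untested is meant among the compounds shown, and "the series" means these compounds.

Measured in an ADME assay on MCF-10A cells (Homo sapiens) for cytotoxicity, read by sulforhodamine B assay, with a stated time of 48 h; a higher number here means a weaker inhibitor of growth, a lower number a stronger inhibitor of growth:
compound 1 `CCN(CC)CN1C(=O)/C(=N\c2nc3ccc(C)cc3s2)c2c(Br)cccc21`, 16100 nM
compound 2 `Cc1ccc2nc(/N=C3\C(=O)N(CN4CCCCC4)c4ccccc43)sc2c1`, 38900 nM
compound 3 `O=C1C(=O)N(CN(c2ccccc2)c2ccccc2)c2cccc(Cl)c21`, 77200 nM

Compound 3 holds the highest of the three numbers in this assay. Against compound 2 the gap stays within the scatter, so nothing separates the two; against compound 1 the gap lies beyond it, so compound 3 is the weaker growth inhibitor of that pair. Among the compounds with values here, no two measured compounds differ in one place only, so no step size is known from the series itself.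

Compound 4 `O=C1C(=O)N(CN(c2ccccc2)c2ccccc2)c2ccccc21` differs from compound 3 by hydrogen in place of chloro on an aromatic carbon. Within the data shown here, with no measured one-place step to lean on, the expectation for this assay rests on the change alone: a small shift, if any, more likely toward a higher number than a lower one, and not beyond the scatter. The expected step is a 1.2-fold higher number from compound 3 to compound 4 (0.09 log units; within the scatter). Compound 4 is therefore expected to give 95000 nM in this assay, with a range from 40000 nM to 220000 nM. Given how high compound 3 already sits, a limit rather than a number is a real possibility.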

Compound 4, concentration for 50% growth inhibition: 73000 nM
Compound 4: middle estimate off by 1.3-fold (0.11 log units), on the high side; measured number inside the range.
By their numbers in this assay, from the lowest: compound 1; then compounds 2, 4 and 3 (each within the scatter of the next).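

In this assay, the series now has its first one-place step: a 1.1-fold lower number from compound 3 to compound 4 (0.02 log units; within the scatter), with hydrogen in place of chloro on an aromatic carbon, ortho to a fused ring and meta to a fused ring. The chloro at this position therefore makes no measurable difference in this pair, and the high number of compound 3 does not depend on it. No measurement shown here accounts for the size of this step.

As far as these compounds go, whether a carboxylic acid, an amine or a methoxy group at this position would leave the number equally unmoved remains open. Also open, from the compounds shown here alone, is whether removing the bromo from compound 1, which carries a diethylaminomethyl group on the ring nitrogen, would give a similarly small step.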